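The compounds below may be only part of what the source reports. "The series", "measured", "known", "first", "only" and "open" are said of these compounds alone.

Measured so far:
Compound 1 `O=C1Nc2ccccc2/C1=N/NC(=S)Nc1ccc(F)cc1` — in an ADME assay on RD cells (Homo sapiens) for cytotoxicity (on this read-out lower numbers stand for higher toxicity in this test and higher numbers for lower toxicity in this test), compound 1 gives > 25000 nM, which is a limit of the assay and not a number.
Compound 2 `O=C1Nc2ccccc2/C1=N/NC(=S)Nc1ccc(Cl)cc1` — in this assay compound 2 gives > 25000 nM, again a limit rather than a number.

Within the data shown here, the only measured step, a step that the two limits leave unreadable from compound 1 to compound 2, is not readable, since (the limit of > 25000 nM in this assay, at which 2 of the 2 values shown sit). Compound 2 thus stands only at a limit, with no number to place it against.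

Next in line is compound 3 `CCNC(=S)N/N=C1\C(=O)Nc2ccccc21`. It differs from compound 2 by ethyl in place of 4-chlorophenyl on an amide-type nitrogen. Among the measured compounds shown here, no measured step touches this position; the step from compound 1 to compound 2 concerns a substituent on the aryl ring and is itself unreadable. Nothing seen so far therefore points to a step beyond the scatter in this assay in either direction. Compound 3 is expected to give about 40000 nM, estimated between 15000 nM and 100000 nM. The expected step is a step that the limit leaves unreadable from compound 2 to compound 3.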

Compound 3, half-maximal cytotoxic concentration: > 25000 nM
Compound 3: no number, only a limit; the forecaster's own chance of this, stated with the estimate: 75%; the middle value lies beyond the limit too.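

Among these compounds, compound 1, compound 2 and compound 3 all sit at the same limit of this assay and give no number, so no step among them can be read. The compounds shown leave open whether 4-fluorophenyl, 4-chlorophenyl or ethyl on the amide-type nitrogen makes any difference to this read-out.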